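Extending the Side Chain From Compound 1 to Compound 3

The source may report more compounds than this note shows. Statements on the series, on what has been measured and on what is new or still open speak of the compounds shown alone.

The two compounds measured so far:
Compound 1, `NC(=O)C[C@H](NC(=O)CN(c1nc(Cl)nc2[nH]cnc12)C1CC1)C(=O)O`, gives 29.7% in a functional assay on the whole organism (Tail, strain ICR) with Mus musculus as the target, in the tail flick test, with a stated time of 30 min, at a dose of 25 umol/kg by the oral route; a higher number here means a stronger effect of the compound at the dose given, a lower number a weaker effect.
Compound 2, `C[C@@H](O)[C@H](NC(=O)CN(c1ncnc2c1ncn2C1CCCCO1)C1CC1)C(=O)OCc1ccccc1`, gives 23.6% in this assay.

Compound 1 shows the higher of the two numbers, but the gap to compound 2 lies within the usual scatter of repeated measurements, so the two results cannot be told apart. The two compounds also differ in several places at once, so their pair says nothing about any single change.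

Compound 3, `NC(=O)CC[C@H](NC(=O)CN(c1nc(Cl)nc2[nH]cnc12)C1CC1)C(=O)O`, has not yet been measured. It differs from compound 1 in one place: carbamoylmethyl in place of carbamoyl on a saturated chain carbon, two bonds along the chain from an amide-type nitrogen and a carbonyl carbon. Cut one bond further out, the same change reads carbamoylmethyl to 2-carbamoylethyl, a chain grown by one saturated carbon on the way to its carbamoyl end.

For the measured compounds named here, no measured pair shows what this change does in this assay. The step of a number 0.7 percentage points lower from compound 1 to compound 3 (within the scatter) is therefore expected to be small, within the scatter, in no preferred direction. Compound 3 is estimated to give 29%, with an expected range from 14% to 44%.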

Compound 3, a percentage reported as activity, at one dose (the size of the read-out at that dose, not a potency): 33.1%
Estimate against measurement, compound 3: 4.1 percentage points below, within the range that was stated.
By their numbers in this assay, from the lowest: compounds 2, 1 and 3 (each within the scatter of the next).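

Growing the side chain by one saturated carbon, carbamoylmethyl to 2-carbamoylethyl, gives the first change at a single place that can be read in this assay, and it amounts to a number 3.4 percentage points higher from compound 1 to compound 3 (within the scatter). At this position on the saturated chain carbon, the two chain lengths therefore cannot be told apart in this read-out, so this one change offers no reason to prefer either one. No independent measurement is available that could explain this result or connect it to any property of the side chain.

For the compounds shown here, this pair covers only two chain lengths with a carbamoyl end, at one dose and one time, and a read-out at one dose is not a potency, so any difference in potency between compound 1 and compound 3 remains unknown. Still open, on these data alone, is whether a longer chain such as 3-carbamoylpropyl, or a different end on the chain, such as a carboxylic acid or an amine in place of the carbamoyl, would move the number beyond the scatter of this assay.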